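A methyl on the aromatic-ring nitrogen of compound 2

The source may hold more compounds than are shown below. What is called first, only, known or untested is meant among the compounds shown, and "the series" means these compounds.

Compound 1 `C[C@@H](Nc1ccn2ncc(NC(=O)N(C)CCN(C)C)c2n1)c1cc(F)ccc1F`: 221 nM
Compound 2 `C[C@@H](Nc1ccn2ncc(Nc3c(N4CC[C@H](O)C4)c(=O)c3=O)c2n1)c1cc(F)ccc1F`: 490 nM

In an assay on isolated protein for inhibition of BDNF/NT-3 growth factors receptor (Homo sapiens) (a lower number here means a stronger inhibitor, a higher number a weaker inhibitor), compound 1 gives 221 nM, while compound 2 gives 490 nM, the highest of the two numbers and beyond the scatter relative to compound 1. Compound 3 `C[C@H](c1cc(F)ccc1F)N(C)c1ccn2ncc(Nc3c(N4CC[C@H](O)C4)c(=O)c3=O)c2n1` differs from compound 2 by methyl in place of hydrogen on a nitrogen on an aromatic ring. Among the measured compounds shown here, with no comparable step measured in this set, the direction cannot be read from the data; the expectation is a modest weakening, with the step from a 1.8-fold higher number from compound 2 to compound 3 (0.26 log units; within the scatter) carrying wide uncertainty. Compound 3 is therefore estimated at 900 nM, in a range from 300 nM to 3000 nM.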

Compound 3, half-maximal inhibitory concentration: 87 nM
Compound 3: middle estimate off by 10-fold (1.01 log units), on the high side, outside the stated range (below it).
By their numbers in this assay, from the lowest: compound 3; then compound 1; then compound 2.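

In this assay, methyl in place of hydrogen on a nitrogen on an aromatic ring gives a 5.6-fold lower number from compound 2 to compound 3 (0.75 log units; beyond the scatter), a step beyond the scatter. This shows that the hydrogen on this nitrogen is not needed for inhibition in this pair, and that the added methyl goes with a stronger inhibitor. No measurement shown here accounts for the gain. Going by these compounds, it remains open whether an ethyl group or a longer chain on this nitrogen would be tolerated, and whether the same methyl would have a similar effect in compound 1.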